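Replacing the 4-fluorophenyl Group of Compound 3

The compounds below may be only part of what the source reports. "The series", "measured", "known", "first", "only" and "open" are said of these compounds alone.

In a functional assay on HepG2 cells (Homo sapiens) for inhibition, read by MTT assay, with a stated time of 48 h (on this read-out lower numbers stand for stronger inhibition and higher numbers for weaker inhibition), compound 1 `COc1ccc(-n2c(SCc3ccc(F)cc3)nnc2-c2cc(OC)c(OC)c(OC)c2)cc1` gives 35000 nM, compound 2 `COc1ccc(-n2c(SCC(=O)c3ccccc3)nnc2-c2cc(OC)c(OC)c(OC)c2)cc1` gives 16200 nM and compound 3 `COc1ccc(-n2c(SCC(=O)c3ccc(F)cc3)nnc2-c2cc(OC)c(OC)c(OC)c2)cc1` gives 10700 nM. Compound 3 therefore sits level with compound 2 within the scatter, while compound 1 stands clearly higher. Placing a carbonyl on the saturated chain carbon bound to a sulfur accounts for the two modest steps, a 2.2-fold lower number from compound 1 to compound 2 (0.33 log units; beyond the scatter) and a 3.3-fold lower number from compound 1 to compound 3 (0.51 log units; beyond the scatter). Compound 4 `COc1ccc(-n2c(SCC(=O)c3ccc(OC)c(O)c3)nnc2-c2cc(OC)c(OC)c(OC)c2)cc1` keeps that carbonyl and changes only the group on it, with 3-hydroxy-4-methoxyphenyl in place of 4-fluorophenyl on a carbonyl carbon. Among the compounds with values here, only one measured step touches this group, the fluoro in place of hydrogen on an aromatic carbon, and it stays within the scatter at a 1.5-fold lower number from compound 2 to compound 3 (0.18 log units; within the scatter). Within the data shown here, no measured compound carries a hydroxy or methoxy on this group, so the evidence is thin. On that basis, no step beyond the scatter is expected in this assay, and the estimated change is a 1.3-fold lower number from compound 3 to compound 4 (0.13 log units; within the scatter). For compound 4 the estimated value is 8000 nM, with an expected range from 2000 nM to 25000 nM.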

Compound 4, half-maximal inhibitory concentration: > 60000 nM
Compound 4: only a limit was reported; the forecaster's own chance of this, stated with the estimate: 5%; middle value at least 7.5-fold (0.87 log units) from the limit.
By their numbers in this assay, from the lowest: compounds 3 and 2 (each within the scatter of the next); then compound 1. At a limit, above all of these: compound 4.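

Compound 4 has only a limit of the assay, not a number: the limit of > 60000 nM in this assay, at which 1 of the 4 values shown sits.

Even so, in this assay the group on the carbonyl carbon, until now seen to change only within the scatter, turns out to carry steps beyond it: an at least 5.6-fold higher number from compound 3 to compound 4 (0.74 log units; beyond the scatter) with 3-hydroxy-4-methoxyphenyl in place of 4-fluorophenyl, and an at least 3.7-fold higher number from compound 2 to compound 4 (0.56 log units; beyond the scatter) with the same group in place of phenyl. The third step, an at least 1.7-fold higher number from compound 1 to compound 4 (0.23 log units; that floor lies within the scatter), has a floor within the scatter, yet it shows that the carbonyl alone does not keep the number low, whatever group it carries.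

The compounds shown leave open whether the hydroxy, the methoxy or the two together carry this step. They also leave open how an amine or a carboxylic acid on this phenyl ring would read in this assay.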